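The source may hold more compounds than are shown below. What is called first, only, known or untested is meant among the compounds shown, and "the series" means these compounds.

Working notes on the series.

Three compounds share the core of compound 1 `CC1CCCC(C(=O)N2CC(c3nc(-c4cccc(Cl)c4)no3)C2)C1` and differ only in the group on the carbonyl carbon. In an assay on HEK293 cells for positive allosteric modulation of metabotropic glutamate receptor 5 (Homo sapiens), read by FLIPR (on this read-out lower numbers stand for an effect already at smaller amounts and higher numbers for an effect only at larger amounts of compound), compound 1 gives 410 nM. Compound 2 `O=C(C1CCC(F)(F)CC1)N1CC(c2nc(-c3cccc(Cl)c3)no2)C1` carries 4,4-difluorocyclohexyl there and in this assay compound 2 gives 180 nM, a change of a 2.3-fold lower number from compound 1 to compound 2 (0.36 log units; beyond the scatter). Compound 3 `O=C(N1CCCCCC1)N1CC(c2nc(-c3cccc(Cl)c3)no2)C1` carries azepan-1-yl, an amide-type nitrogen in a ring joined directly to the carbonyl, and in this assay compound 3 gives 47 nM; this is the lowest of the three numbers, with steps of an 8.7-fold lower number from compound 1 to compound 3 (0.94 log units; beyond the scatter) and a 3.8-fold lower number from compound 2 to compound 3 (0.58 log units; beyond the scatter), both beyond the scatter.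

Compound 4 `CC1CCN(C(=O)N2CC(c3nc(-c4cccc(Cl)c4)no3)C2)CC1` is next. The change from compound 3 is 4-methylpiperidin-1-yl in place of azepan-1-yl on a carbonyl carbon. Unlike the earlier steps, which swapped a ring carbon on the carbonyl for a ring nitrogen, this one keeps the ring nitrogen on the carbonyl and only reshapes the ring, so none of the measured steps applies directly; they bracket the amide-to-urea change, not a change of ring size within the urea. Going by the values given here, with no direct precedent, the expected step is small, a 1.3-fold higher number from compound 3 to compound 4 (0.11 log units; within the scatter), and a change within the scatter would not surprise. Compound 4 is therefore estimated at 60 nM, with a range from 20 nM to 180 nM.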

Compound 4, half-maximal effective concentration: 865 nM
Beside the measured number, compound 4's estimate is 14-fold (1.16 log units) below it, outside the stated range (above it).
By their numbers in this assay, from the lowest: compound 3; then compound 2; then compound 1; then compound 4.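

In this assay, the position proves sensitive to ring shape even with the atoms held constant: an 18-fold higher number from compound 3 to compound 4 (1.26 log units; beyond the scatter) comes from replacing azepan-1-yl with 4-methylpiperidin-1-yl, two groups with the same heavy-atom count, joined differently. A ring nitrogen on the carbonyl therefore does not by itself go with the low number of compound 3: compound 4 carries one too, yet it has the highest number of the four, with a 4.8-fold higher number from compound 2 to compound 4 (0.68 log units; beyond the scatter) and a 2.1-fold higher number from compound 1 to compound 4 (0.32 log units; beyond the scatter) from the two groups joined through ring carbon. No available data bear on the reason for these steps.

The compounds shown leave open whether the higher number of compound 4 goes with the six-membered ring or with its methyl group, and piperidin-1-yl without the methyl would separate the two. They also leave open how 4,4-difluoropiperidin-1-yl would compare with the 4,4-difluorocyclohexyl group of compound 2, and whether a smaller ring such as pyrrolidin-1-yl would extend the dependence on ring size.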